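The source may report more compounds than this note shows. Statements on the series, on what has been measured and on what is new or still open speak of the compounds shown alone.

Measured compounds:
compound 1 `CC(C)[C@H](NC(=O)COc1cccc2ccccc12)C(=O)N[C@@H](CC(=O)O)C(=O)COC(=O)c1c(Cl)cccc1Cl` — 10600 nM
compound 2 `CC(C)[C@H](NC(=O)COc1cccc2ccccc12)C(=O)N[C@@H](CC(=O)O)C(=O)COc1ccc(C(F)(F)F)cc1` — > 100000 nM

In a functional assay on Jurkat cells (Homo sapiens) (on this read-out higher numbers stand for weaker inhibition and lower numbers for stronger inhibition), compound 1 gives 10600 nM. From the compounds shown here alone, compound 2 reaches only the limit of this assay, > 100000 nM, so its true number is unknown (the limit of > 100000 nM in this assay, at which 1 of the 2 values shown sits). Compound 3 `CC(C)[C@H](NC(=O)COc1cccc2ccccc12)C(=O)N[C@@H](CC(=O)O)C(=O)COc1c(F)c(F)c(F)c(F)c1F` differs from compound 2 by 2,3,4,5,6-pentafluorophenyl in place of 4-(trifluoromethyl)phenyl on an oxygen on a saturated carbon. Going by the values given here, no measured step covers this change; the only measured step, an at least 9.4-fold higher number from compound 1 to compound 2 (0.97 log units; beyond the scatter), alters the same position but with different groups, so it gives no direction for compound 3. Compound 3 is therefore expected near where compound 2 stands, with wide uncertainty, at an estimated 15000 nM (range 1000 nM to 150000 nM), a step of an at least 6.6-fold lower number from compound 2 to compound 3 (0.82 log units; beyond the scatter).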

Compound 3, half-maximal inhibitory concentration: 3050 nM
Estimate against measurement, compound 3: 4.9-fold (0.69 log units) above; low and high end bracket the measured number.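

At this place, on an oxygen on a saturated carbon, the choice of fluorinated ring matters greatly in this assay: 2,3,4,5,6-pentafluorophenyl in place of 4-(trifluoromethyl)phenyl gives an at least 32-fold lower number from compound 2 to compound 3 (1.51 log units; beyond the scatter). Compound 2 is only a limit, so this step has a minimum size but no exact one: the limit of > 100000 nM in this assay, at which 1 of the 3 values shown sits. Replacing (2,6-dichlorophenyl)carbonyl with the same pentafluorophenyl ring gives a 3.5-fold lower number from compound 1 to compound 3 (0.54 log units; beyond the scatter), so a phenyl ring here can outdo that carbonyl group, although compound 2 goes against this.

From the compounds shown here alone, how much of the gain depends on the number of fluorine atoms remains open. A plain phenyl ring or a phenyl ring bearing a single chlorine atom would help to test this.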